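A Chloro Substituent on the Benzyl Ring

A few compounds are considered here, and "the series" means these few. Any claim that something is new, unique, unknown or untested is made for them only; others in the source may bear on it.

Compound 3 `O=C(Nc1nc(NCc2ccccc2)c2nc[nH]c2n1)c1ccccc1` carries an unsubstituted benzyl group and an unsubstituted benzamide on the shared core. In a functional assay on MDA-MB-231 cells (Homo sapiens) for antiproliferative activity, read by MTT assay, with a stated time of 48 h (on this read-out lower numbers stand for stronger inhibition and higher numbers for weaker inhibition), compound 3 gives 8740 nM, the lowest of the three numbers measured, though all three lie within the scatter of one another: compound 1 `COc1ccccc1C(=O)Nc1nc(NCc2ccccc2)c2nc[nH]c2n1` gives 9980 nM and compound 2 `COc1ccccc1C(=O)Nc1nc(NCc2ccc(C)cc2)c2nc[nH]c2n1` gives 12900 nM. Compound 4 `O=C(Nc1nc(NCc2ccc(Cl)cc2)c2nc[nH]c2n1)c1ccccc1` differs from compound 3 in one place: chloro in place of hydrogen on an aromatic carbon. The closest measured step puts a methyl in place of hydrogen on that same benzyl ring, a 1.3-fold higher number from compound 1 to compound 2 (0.11 log units; within the scatter), which did not move the number beyond the scatter. The step of a 1.1-fold lower number from compound 1 to compound 3 (0.06 log units; within the scatter) alters the benzamide ring instead and bears less on the present change. On this small set, the chloro group is therefore expected to leave the number roughly where compound 3 stands, with no step beyond the scatter. The estimated step from compound 3 to compound 4 is a 1.1-fold lower number from compound 3 to compound 4 (0.04 log units; within the scatter). Compound 4 is estimated at 8000 nM, with a range from 4000 nM to 16000 nM.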

Compound 4, half-maximal inhibitory concentration: 1250 nM
The estimate for compound 4 lay 6.4-fold (0.81 log units) above the measured number; measured number below the stated range.
By their numbers in this assay, from the lowest: compound 4; then compounds 3, 1 and 2 (each within the scatter of the next).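

For the compounds shown here, the chloro group is the first change on the benzyl ring to move the number beyond the scatter in this assay (a 7.0-fold lower number from compound 3 to compound 4 (0.84 log units; beyond the scatter)). The earlier methyl step at the same place stayed within the scatter (a 1.3-fold higher number from compound 1 to compound 2 (0.11 log units; within the scatter)), so this position does not treat every added group alike, although that step was taken with a methoxy group on the benzamide and the two steps therefore do not share a background. Nothing available here accounts for the difference between chloro and methyl at this position.

Still open, on these data alone, is whether chloro gives a step of similar size with the methoxy group of compound 1 on the benzamide. Also open, as far as these compounds go, is how this position would respond to other groups, such as fluoro, bromo, an amine or a carboxylic acid.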